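Sulfonamide swap on the aryl sulfonyl of compound 3

The source may hold more compounds than are shown below. What is called first, only, known or untested is meant among the compounds shown, and "the series" means these compounds.

Measured so far:
Compound 1, `CCN(CC)S(=O)(=O)c1ccc(S(=O)(=O)N2CCC[C@@H](C(=O)N3CCN(c4nc(C)no4)CC3)C2)cc1`, 250 nM in a functional assay on MIA PaCa-2 cells (Homo sapiens) for inhibition, read by MTT assay, with a stated time of 7 days; a lower number here means a stronger inhibitor, a higher number a weaker inhibitor.
Compound 2, `CCN(CC)S(=O)(=O)c1ccc(S(=O)(=O)N2CCC[C@@H](C(=O)N3CCN(C(=O)OC(C)(C)C)CC3)C2)cc1`, 70 nM in this assay.
Compound 3, `CC(C)c1noc(N2CCN(C(=O)[C@@H]3CCCN(S(=O)(=O)c4ccc(S(=O)(=O)NC(C)(C)C)cc4)C3)CC2)n1`, 300 nM in this assay.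

Compound 3 carries the highest of the three numbers; against compound 1 the gap is within the scatter, against compound 2 it is beyond it. For the measured compounds named here, the one step between single-change neighbours, a 3.6-fold lower number from compound 1 to compound 2 (0.55 log units; beyond the scatter), concerns the amine nitrogen in the ring and not the sulfonyl group. Compound 4, `CCN(CC)S(=O)(=O)c1ccc(S(=O)(=O)N2CCC[C@@H](C(=O)N3CCN(c4nc(C(C)C)no4)CC3)C2)cc1`, differs from compound 3 by diethylamino in place of (tert-butyl)amino on a sulfonyl sulfur. Going by the values given here, no measured step touches this place, and compound 1 and compound 3, which differ in two places including this one, show numbers within the scatter of each other. The step from compound 3 to compound 4 is therefore expected to stay within the scatter, a 1.2-fold lower number from compound 3 to compound 4 (0.08 log units; within the scatter). Compound 4 is estimated at 250 nM, ranging from 100 nM to 700 nM.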

Compound 4, half-maximal inhibitory concentration: 50 nM
For compound 4 the middle estimate is 5.0-fold (0.70 log units) above the measured one; measured number outside the range, below it.
By their numbers in this assay, from the lowest: compounds 4 and 2 (each within the scatter of the next); then compounds 1 and 3 (each within the scatter of the next).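

For the compounds shown here, on a sulfonyl sulfur, diethylamino in place of (tert-butyl)amino is the first measured change at this place, and it moves the number beyond the scatter (a 6.0-fold lower number from compound 3 to compound 4 (0.78 log units; beyond the scatter)). With diethylamino held, isopropyl in place of methyl on an aromatic carbon also matters (a 5.0-fold lower number from compound 1 to compound 4 (0.70 log units; beyond the scatter)), while 3-isopropyl-1,2,4-oxadiazol-5-yl and tert-butoxycarbonyl on the amine nitrogen in a ring stay within the scatter of each other (a 1.4-fold lower number from compound 2 to compound 4 (0.15 log units; within the scatter)). No evidence bearing on either shift is available.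

Open: how dimethylamino or an unsubstituted amino group on the sulfonyl sulfur would compare with diethylamino. Also open, from the compounds shown here alone, is whether the sulfonyl step holds with other groups on the amine nitrogen in a ring.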